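The source may hold more compounds than are shown below. What is called first, only, known or untested is meant among the compounds shown, and "the series" means these compounds.

Measured so far:
compound 1, `CC[C@H]1OC(=O)[C@H](C)[C@@H](O[C@H]2C[C@@](C)(OC)[C@@H](O)[C@H](C)O2)[C@H](C)[C@@H](O[C@@H]2O[C@H](C)C[C@H](N(C)CCCNC(C)=O)[C@H]2O)[C@](C)(OC)C[C@@H](C)C(=O)[C@H](C)[C@@H](O)[C@]1(C)O`, in a physicochemical assay for lipophilicity, read by HPLC, measured as chromatographic lipophilicity, at pH 7.4 (on this read-out higher numbers stand for higher lipophilicity and lower numbers for lower lipophilicity), gives 3.08.
compound 2, `CC[C@H]1OC(=O)[C@H](C)[C@@H](O[C@H]2C[C@@](C)(OC)[C@@H](O)[C@H](C)O2)[C@H](C)[C@@H](O[C@@H]2O[C@H](C)C[C@H](N(C)C)[C@H]2O)[C@](C)(O)C[C@@H](C)CN(C)[C@H](C)[C@@H](OCCCNC(=O)C2CCC2)[C@]1(C)O`, in this assay gives 3.5.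

Compound 2 stands highest of the two numbers; compound 1 sits lower, and the gap lies beyond the scatter. Compound 3, `CCCCCCCC(=O)NCCCO[C@@H]1[C@@H](C)N(C)C[C@H](C)C[C@@](C)(O)[C@H](O[C@@H]2O[C@H](C)C[C@H](N(C)C)[C@H]2O)[C@@H](C)[C@H](O[C@H]2C[C@@](C)(OC)[C@@H](O)[C@H](C)O2)[C@@H](C)C(=O)O[C@H](CC)[C@@]1(C)O`, is not yet measured in this assay. It differs from compound 2 in one place: heptyl in place of cyclobutyl on a carbonyl carbon. Within the data shown here, no step between measured compounds covers a change of this kind, so the expectation rests on the change alone. An upward step beyond the scatter is expected, a number 1.20 log units higher from compound 2 to compound 3 (beyond the scatter). Compound 3 is estimated at 4.7, with a range of 4.2 to 5.3.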

Compound 3, distribution coefficient: 5.18
Compound 3: middle estimate off by 0.48 log units, on the low side; the measured number falls inside the stated range.
By their numbers in this assay, from the lowest: compound 1; then compound 2; then compound 3.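

On a carbonyl carbon bonded to an amide-type nitrogen, heptyl in place of cyclobutyl gives a number 1.68 log units higher from compound 2 to compound 3 (beyond the scatter) in this assay. Among these compounds, this is the only single-place step so far, and it shows that the group at this position can shift the read-out by a large amount, well beyond the scatter. Nothing available explains the size of this step.

Open: whether butyl or a longer chain such as decyl would separate the effect of chain length from the loss of the ring. Going by these compounds, also open: how an amine or a carboxylic acid at the end of the heptyl chain would read.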